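This account rests on a few compounds, and the source may have more. Where it says the series, first, only, none or still open, it means among the compounds named here.

The study centres on a shared core carrying an ester side chain, and varies only the alcohol part of that ester. Compound 1 `CCCCc1nc(C)c(CC(=O)OCC)c(=O)n1Cc1ccc(-c2ccccc2-c2noc(=O)[nH]2)cc1` bears an ethyl ester, and in an ADME assay on microsomes from liver (Homo sapiens) for metabolic stability, with a stated time of 30 min (a lower number here means that less of the compound is left, a higher number that more of the compound is left), compound 1 gives 46.6%; 46.5% (2 entries), two repeat entries that agree closely (the several entries of compound 1 in this assay, 46.6%; 46.5% (2 entries)). Among the compounds with values here, compound 2 `CCCCc1nc(C)c(CC(=O)OC(C)C)c(=O)n1Cc1ccc(-c2ccccc2-c2noc(=O)[nH]2)cc1` carries an isopropyl ester instead, and in this assay compound 2 gives 17.5%, the only number recorded for it; one further entry exists for compound 2 without a single number. Set against compound 1, the value of compound 2 lies well below it, so of the two measured compounds it is compound 2 that leaves the smaller fraction behind after the stated time.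

Compound 3 `CCCCOC(=O)Cc1c(C)nc(CCCC)n(Cc2ccc(-c3ccccc3-c3noc(=O)[nH]3)cc2)c1=O` extends the series by one more ester: butyl in place of isopropyl on an oxygen next to a carbonyl group. Within the data shown here, no measured step of this kind is available, so the size of the change can only be expected, not read off. The account expects the move from compound 2 to compound 3 to bring little change in this assay, a step of a number 3.5 percentage points lower from compound 2 to compound 3 (within the scatter) that stays within the scatter or drifts slightly lower. For compound 3 the expected result in this assay is 14%, with a range from 5% to 30%.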

Compound 3, percent of the compound remaining: 2.8%
For compound 3 the middle estimate is 11.2 percentage points above the measured one; measured number below the stated range.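

In this assay, this step shows that the alcohol part of the ester can move the result beyond the scatter even when no ring, hydrogen-bond donor, hydrogen-bond acceptor or net charge is involved: butyl in place of isopropyl on an oxygen next to a carbonyl group gives a number 14.7 percentage points lower from compound 2 to compound 3 (beyond the scatter). The swap adds a single carbon to the group, yet it leaves compound 3 at 2.8%, so a small change at this position is enough to alter the share of compound remaining. Nothing in the information at hand explains why this exchange has such an effect.

Isopropyl is branched and butyl is a straight chain with one more carbon, so the compounds shown cannot separate the effect of branching from that of chain length. Going by these compounds, it also remains open how a propyl or tert-butyl group on this oxygen would behave in this assay, or how a carboxylic acid or an amide would compare with the ester.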